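Taking the hydroxy group away from compound 3

A few compounds are considered here, and "the series" means these few. Any claim that something is new, unique, unknown or untested is made for them only; others in the source may bear on it.

Values so far in a functional assay on HCT-116 cells (Homo sapiens) for inhibition, read by MTT assay, with a stated time of 48 h; a lower number here means a stronger inhibitor, a higher number a weaker inhibitor
compound 1 `C/C=C/C(=O)N(Cc1ccc(OC)c(Br)c1)c1cc(OC)c(OC)c(OC)c1` gives 2800 nM
compound 2 `C/C=C/C(=O)N(Cc1cccc(O)c1)c1cc(OC)c(OC)c(OC)c1` gives 6700 nM
compound 3 `C/C=C/C(=O)N(Cc1ccc(OC)c(O)c1)c1cc(OC)c(OC)c(OC)c1` gives 55 nM

Compound 3 at 55 nM holds the lowest of the three numbers, and its steps to both other compounds lie beyond the scatter. Compound 4 `C/C=C/C(=O)N(Cc1ccc(OC)cc1)c1cc(OC)c(OC)c(OC)c1` has not yet been measured. Against compound 3 it carries the change hydrogen in place of hydroxy on an aromatic carbon in which hydrogen takes the place of hydroxy on an aromatic carbon, ortho to a methoxy group, so that 3-hydroxy-4-methoxyphenyl becomes 4-methoxyphenyl.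

Within the data shown here, two measured steps bear on this. Hydroxy in place of bromo gave a 51-fold lower number from compound 1 to compound 3 (1.71 log units; beyond the scatter) and this large step is the closest guide, although bromo is not hydrogen. Methoxy in place of hydrogen on an aromatic carbon gave a 120-fold lower number from compound 2 to compound 3 (2.09 log units; beyond the scatter) and this step, also large, shows that the hydroxy alone did not bring the low number. Among the measured compounds shown here, no measured compound keeps the methoxy with hydrogen where compound 3 has its hydroxy, so the size of the step remains uncertain.

A large step towards a higher number is therefore expected in this assay because compound 1 gives 2800 nM without that hydroxy. The expected change is a 27-fold higher number from compound 3 to compound 4 (1.44 log units; beyond the scatter) according to this estimate. Compound 4 is estimated at 1500 nM with 300 nM as the expected lower end and 7000 nM as the upper end.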

Compound 4, half-maximal inhibitory concentration: 500 nM
Beside the measured number, compound 4's estimate is 3.0-fold (0.48 log units) above it; low and high end bracket the measured number.
By their numbers in this assay, from the lowest: compound 3; then compound 4; then compound 1; then compound 2.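

In this assay, hydrogen on this aromatic carbon supplies the reference point that the bromo compound could not: the loss of the hydroxy gives a 9.1-fold higher number from compound 3 to compound 4 (0.96 log units; beyond the scatter), a modest step, so the hydroxy lowers the number, yet much of the low reading survives without it. Bromo also proves to be no stand-in for hydrogen at this position, as hydrogen in place of bromo gives a 5.6-fold lower number from compound 1 to compound 4 (0.75 log units; beyond the scatter), which orders the three groups on this carbon as hydroxy, hydrogen, bromo, starting from the lowest number, with the methoxy group kept in all three compounds. Setting 4-methoxyphenyl against 3-hydroxyphenyl gives a 13-fold lower number from compound 2 to compound 4 (1.13 log units; beyond the scatter), a large step against the modest one for the hydroxy, so among these four compounds the methoxy group accounts for more of the low number than the hydroxy does.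

Nothing available explains why these groups rank as they do. Going by these compounds, it remains open how an amino group, a fluorine atom or a hydroxymethyl group on this same carbon would rank against hydroxy, hydrogen and bromo, and whether the ranking would hold with an ethoxy group in place of the methoxy group.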